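The source may hold more compounds than are shown below. What is called first, only, known or untested is meant among the compounds shown, and "the series" means these compounds.

Measured compounds in an assay on isolated protein for displacement of a labelled ligand from 5-hydroxytryptamine receptor 6 (Homo sapiens); on this read-out higher numbers stand for weaker inhibition and lower numbers for stronger inhibition:
compound 1 `NC[C@@H]1CCCc2cc(S(=O)(=O)c3cccc(F)c3)ccc21` — 0.0794 nM
compound 2 `Cn1ccc(S(=O)(=O)c2ccc3c(c2)CCC[C@H]3CN)c1` — 7.94 nM
compound 3 `NC[C@@H]1CCCc2cc(S(=O)(=O)c3cn[nH]c3)ccc21` — 2 nM

Compound 1 holds the lowest number of the three. Against it, compound 3 sits at a 25-fold higher number from compound 1 to compound 3 (1.40 log units; beyond the scatter) and compound 2 at a 100-fold higher number from compound 1 to compound 2 (2.00 log units; beyond the scatter); between those two, a 4.0-fold lower number from compound 2 to compound 3 (0.60 log units; beyond the scatter). Every one of these steps concerns the group on the sulfonyl sulfur, while the primary amine on the saturated chain carbon is kept unchanged in all three.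

Compound 4 `O=C1CN=C(NC[C@@H]2CCCc3cc(S(=O)(=O)c4cccc(F)c4)ccc32)N1` departs from compound 1 elsewhere: a group of 6 heavy atoms (3 carbon, 2 nitrogen, 1 oxygen; one five-membered non-aromatic ring with 2 hetero atoms) in place of a hydrogen atom, on an amine nitrogen. Among the measured compounds shown here, no measured step touches this nitrogen, so the three steps above give no direct guide to its size or direction. What they do show is that this series is sensitive to changes at the periphery, with large shifts in this assay for single substitutions. The amine has so far been a constant feature among the measured compounds, and replacing its hydrogen with a substantial group is a change of a kind not yet sampled. A step weakening binding is expected, of uncertain size, with a wide range allowed.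

For compound 4 the expected result is 1 nM, estimated between 0.1 nM and 12 nM, corresponding to an expected step of a 13-fold higher number from compound 1 to compound 4 (1.10 log units; beyond the scatter).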

Compound 4, inhibition constant: 0.1 nM
Estimate against measurement, compound 4: 10-fold (1.00 log units) above, and the stated range covers the measured number.
By their numbers in this assay, from the lowest: compounds 1 and 4 (each within the scatter of the next); then compound 3; then compound 2.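

In this assay, a group of 6 heavy atoms (3 carbon, 2 nitrogen, 1 oxygen; one five-membered non-aromatic ring with 2 hetero atoms) in place of a hydrogen atom on the amine nitrogen gives a 1.3-fold higher number from compound 1 to compound 4 (0.10 log units; within the scatter) and so leaves the two numbers indistinguishable. The free primary amine of compound 1 is therefore not a requirement for a sub-nanomolar number in this series, at least with the 3-fluorophenyl group on the sulfonyl sulfur, and this nitrogen accepts a substantial ring-bearing group, whereas each change on the sulfonyl sulfur gave a step beyond the scatter. Nothing on hand accounts for this result.

The compounds shown leave open whether the same group on the amine nitrogen would hold its number with the 1H-pyrazol-4-yl group of compound 3 or the 1-methyl-1H-pyrrol-3-yl group of compound 2 on the sulfonyl sulfur. They also leave open how far this nitrogen accepts other groups, such as a single methyl, an acetyl or a longer chain.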